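Moving a Hydroxy Group on the Phenyl Ring

The source may hold more compounds than are shown below. What is called first, only, known or untested is meant among the compounds shown, and "the series" means these compounds.

Measured in a functional assay (mast cells) for inhibition, with Rattus norvegicus as the target; a lower number here means that less compound is needed, a higher number that more compound is needed for the effect:
- compound 1 `CC1CC/C(=N\Nc2ccccc2F)c2ncc(C(=O)O)c(=O)n21`: 1200 nM
- compound 2 `CC1CC/C(=N\Nc2ccc(F)cc2)c2ncc(C(=O)O)c(=O)n21`: 1200 nM
- compound 3 `CC1CC/C(=N\Nc2ccccc2O)c2ncc(C(=O)O)c(=O)n21`: 208000 nM

Compound 3 has the highest number of the three, so it needs the most compound for the effect. The next structure, compound 4 `CC1CC/C(=N\Nc2ccc(O)cc2)c2ncc(C(=O)O)c(=O)n21`, has 4-hydroxyphenyl in place of 2-hydroxyphenyl on an amine nitrogen.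

Within the data shown here, three measured steps bear on this change. The same swap made with fluoro gave no change at the digits printed from compound 1 to compound 2 (within the scatter). Bringing in hydroxy gave much larger steps: a 170-fold higher number from compound 1 to compound 3 (2.24 log units; beyond the scatter) and a 170-fold higher number from compound 2 to compound 3 (2.24 log units; beyond the scatter). The data cannot show whether that rise follows any hydroxy group or only 2-hydroxyphenyl. In the first case, compound 4 would stay close to compound 3 at 208000 nM. In the second, it would return toward compound 2 at 1200 nM.

A drop in this assay is therefore expected, of uncertain size, and the estimated step is a 14-fold lower number from compound 3 to compound 4 (1.14 log units; beyond the scatter). The estimate for compound 4 is 15000 nM, with an expected range of 1000 nM to 200000 nM.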

Compound 4, half-maximal effective concentration: 1300 nM
Compound 4: the middle estimate sits 12-fold (1.06 log units) above what was measured; the measured number falls inside the stated range.
By their numbers in this assay, from the lowest: compounds 1, 2 and 4 (each within the scatter of the next); then compound 3.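

Moving the hydroxy group alone, with the same atoms, gives a 160-fold lower number from compound 3 to compound 4 (2.20 log units; beyond the scatter) in this assay, so the high number belongs to 2-hydroxyphenyl and not to every hydroxy group. With the group placed as in 4-hydroxyphenyl, hydroxy in place of fluoro gives a 1.1-fold higher number from compound 2 to compound 4 (0.03 log units; within the scatter) and the change from 2-fluorophenyl gives a 1.1-fold higher number from compound 1 to compound 4 (0.03 log units; within the scatter) as well. The same swap of fluoro for hydroxy thus has very different outcomes starting from 2-fluorophenyl and from 4-fluorophenyl: the same change on two cores in this assay, a 170-fold higher number (2.24 log units; beyond the scatter) from compound 1 to compound 3 and a 1.1-fold higher number (0.03 log units; within the scatter) from compound 2 to compound 4, 160-fold (2.20 log units) apart, beyond the scatter of two such steps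

Going by these compounds, whether 2-methoxyphenyl or 2-aminophenyl would behave like 2-hydroxyphenyl or like 2-fluorophenyl stays open, as does where 3-hydroxyphenyl would fall. These numbers also do not tell why the 2-hydroxyphenyl compound alone needs so much more compound for the effect.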